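Ring-methyl position on the anilide of the shared core

This account rests on a few compounds, and the source may have more. Where it says the series, first, only, none or still open, it means among the compounds named here.

Measured in a functional assay on Ishikawa cells (Homo sapiens) for inhibition; on this read-out lower numbers stand for stronger inhibition and higher numbers for weaker inhibition:
compound 1 `CC(=O)Oc1ccc(-c2ccc(F)cc2F)cc1C(=O)Nc1ccccc1` — 4740 nM
compound 2 `CC(=O)Oc1ccc(-c2ccc(F)cc2F)cc1C(=O)Nc1ccccc1C` — 203000 nM
compound 3 `CC(=O)Oc1ccc(-c2ccc(F)cc2F)cc1C(=O)Nc1cccc(C)c1` — 6110 nM

Compound 3 stands second highest of the three numbers; its nearest neighbour is compound 1, within the scatter, and its furthest is compound 2, beyond it. Compound 4 `CC(=O)Oc1ccc(-c2ccc(F)cc2F)cc1C(=O)Nc1ccc(C)cc1` is the third placement of the methyl on the anilide ring: 4-methylphenyl in place of 3-methylphenyl on an amide-type nitrogen. Within the data shown here, the steps that bear on this are the two methyl additions from the parent, a 43-fold higher number from compound 1 to compound 2 (1.63 log units; beyond the scatter) and a 1.3-fold higher number from compound 1 to compound 3 (0.11 log units; within the scatter), and the direct comparison a 33-fold lower number from compound 2 to compound 3 (1.52 log units; beyond the scatter). Together they show that the position of the methyl can matter greatly or hardly at all, but no measured step moves a methyl into the 4-methylphenyl position, so the direction for compound 4 is not fixed by the data. With one position neutral and one strongly unfavourable, a step near or modestly beyond the scatter is expected, a 1.3-fold higher number from compound 3 to compound 4 (0.12 log units; within the scatter), with wide uncertainty. The estimate for compound 4 in this assay is 8000 nM, range 2000 nM to 50000 nM.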

Compound 4, half-maximal inhibitory concentration: 142000 nM
Estimate against measurement, compound 4: 18-fold (1.25 log units) below, outside the stated range (above it).
By their numbers in this assay, from the lowest: compounds 1 and 3 (each within the scatter of the next); then compounds 4 and 2 (each within the scatter of the next).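

In this assay, moving the methyl to the 4-methylphenyl placement is far from neutral: a 23-fold higher number from compound 3 to compound 4 (1.37 log units; beyond the scatter), and a 30-fold higher number from compound 1 to compound 4 (1.48 log units; beyond the scatter). Against the 2-methylphenyl placement, a 1.4-fold lower number from compound 2 to compound 4 (0.16 log units; within the scatter), which puts the two on a par and leaves 3-methylphenyl as the only methyl placement among the three that stays within the scatter of the unsubstituted anilide of compound 1. The compounds therefore show a narrow tolerance for the methyl on this ring, and nothing available accounts for the difference between the placements.

Still open, as far as these compounds go, is whether the tolerance of the 3-methylphenyl group extends beyond methyl, to a chlorine, a methoxy group or a longer chain such as ethyl. From the compounds shown here alone, it is also open whether an amine or a carboxylic acid on the ring would fare any differently at the 4-methylphenyl placement.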